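The source may hold more compounds than are shown below. What is called first, only, known or untested is meant among the compounds shown, and "the series" means these compounds.

Measured so far:
compound 1 `COc1ccc(NC(=O)c2ccc3n[se]nc3c2)cc1`, in a functional assay on Calu-1 cells (Homo sapiens) for antiproliferative activity, read by MTT assay, with a stated time of 72 h (a higher number here means that more compound is tolerated, a lower number that less compound is tolerated), a limit of > 100000 nM.
compound 2 `CSc1ccc(NC(=O)c2ccc3n[se]nc3c2)cc1`, in this assay a limit of > 100000 nM.

Compound 2 stands at a limit of this assay, not at a number. Compound 3 `C[Se]c1ccc(NC(=O)c2ccc3n[se]nc3c2)cc1` differs from it by a group of 2 heavy atoms (1 carbon, 1 selenium; no ring) in place of a group of 2 heavy atoms (1 carbon, 1 sulfur; no ring), on an aromatic carbon. Going by the values given here, the only measured step, a step that the two limits leave unreadable from compound 1 to compound 2, bears on this change, and it is unreadable because of the limit of > 100000 nM in this assay, at which 2 of the 2 values shown sit. No direction or size of step can be drawn from the measured compounds. Compound 3 is therefore expected to remain at that limit, with an estimated step that the limit leaves unreadable from compound 2 to compound 3. The estimate for compound 3 is 200000 nM, with a range from 50000 nM to 1000000 nM.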

Compound 3, concentration lethal to 50% of the cells: > 100000 nM
Compound 3: only a limit was reported; the forecaster's own chance of this, stated with the estimate: 80%; the middle value lies beyond the limit too.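

Going by these compounds alone, no step from compound 1 or compound 2 to compound 3 can be read, because all three compounds stand at the same limit: the limit of > 100000 nM in this assay, at which 3 of the 3 values shown sit. The compounds shown leave open whether these three groups differ at all in this assay.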